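Swapping Isopropyl for Bromo on the Aryl Ring

This account rests on a few compounds, and the source may have more. Where it says the series, first, only, none or still open, it means among the compounds named here.

Compound 1 `CC(C)c1ccc(-c2nc(SCc3cn(CC(=O)NC(=O)Nc4ccccn4)nn3)nc(Nc3cccc(C(F)(F)F)c3)c2C#N)cc1` gives 24200 nM in a functional assay on ECa-109 cells (Homo sapiens) for inhibition, read by MTT assay, with a stated time of 72 h; a lower number here means a stronger inhibitor, a higher number a weaker inhibitor.
Compound 2 `CC(C)c1ccc(-c2nc(SCc3cn(CC(=O)NC(=O)Nc4ccccn4)nn3)nc(Nc3ccccc3)c2C#N)cc1` reaches only the limit of this assay, > 64000 nM, which is a boundary rather than a number.
Compound 3 `COc1ccc(Nc2nc(SCc3cn(CC(=O)NC(=O)Nc4ccccn4)nn3)nc(-c3ccc(C(C)C)cc3)c2C#N)cc1` gives 5420 nM in this assay.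

Among the two numbers known, compound 1 stands at the weaker end; compound 3 sits a 4.5-fold lower number from compound 1 to compound 3 (0.65 log units; beyond the scatter). Compound 2 reaches only a limit, and its value the limit of > 64000 nM in this assay, at which 1 of the 3 values shown sits, marks the boundary of what this assay can report.

The step to compound 4 `N#Cc1c(Nc2cccc(C(F)(F)F)c2)nc(SCc2cn(CC(=O)NC(=O)Nc3ccccn3)nn2)nc1-c1ccc(Br)cc1` is bromo in place of isopropyl on an aromatic carbon. This changes the ring that carries the isopropyl group, para to a large group, whereas every measured step (an at least 2.6-fold higher number from compound 1 to compound 2 (0.42 log units; beyond the scatter), a 4.5-fold lower number from compound 1 to compound 3 (0.65 log units; beyond the scatter), an at least 11-fold lower number from compound 2 to compound 3 (1.07 log units; beyond the scatter)) alters the other aromatic ring, the one attached to nitrogen. Going by the values given here, none of the measured steps therefore bears directly on this change, so no direction can be drawn from them. The expectation for compound 4 is a step of about a 1.0-fold lower number from compound 1 to compound 4 (0.00 log units; within the scatter), within the scatter. Compound 4 is estimated at 24000 nM, in a range from 8000 nM to 70000 nM.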

Compound 4, half-maximal inhibitory concentration: 2960 nM
Compound 4: the middle estimate sits 8.1-fold (0.91 log units) above what was measured; measured number outside the range, below it.
By their numbers in this assay, from the lowest: compounds 4 and 3 (each within the scatter of the next); then compound 1. At a limit, above all of these: compound 2.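

Changing 4-isopropylphenyl to 4-bromophenyl gives an 8.2-fold lower number from compound 1 to compound 4 (0.91 log units; beyond the scatter) in this assay, the first measured sign that this aromatic ring matters as well as the one attached to nitrogen. The place para to a large group therefore responds to substitution, and here a single bromine atom in place of the three carbons of isopropyl gives the stronger inhibitor of this pair. No measurement shown explains why this swap lowers the number.

The compounds shown leave open whether chloro, an amine or a carboxylic acid at this place would match bromo, or whether plain hydrogen would do as well. They also leave open whether the same swap would give a similar step with the 4-methoxyphenyl of compound 3 on the nitrogen.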